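Changing the Ether Link to a Benzylamine Link

The compounds below may be only part of what the source reports. "The series", "measured", "known", "first", "only" and "open" are said of these compounds alone.

Measured compounds:
- compound 1, `CCOC(=O)[C@H](CCC(=O)O)NC(=O)c1ccc(Sc2nc3cc(N)cc(N)c3nc2-c2ccccc2)cc1`: < 100000 nM
- compound 2, `Nc1cc(N)c2nc(-c3ccccc3)c(Sc3ccc(F)cc3)nc2c1`: 30200 nM
- compound 3, `Nc1cc(N)c2nc(-c3ccccc3)c(Oc3ccc(F)cc3)nc2c1`: 38900 nM

In a functional assay on SF-295 cells (Homo sapiens) for inhibition, read by sulforhodamine B assay, with a stated time of 48 h (a higher number here means a weaker inhibitor of growth, a lower number a stronger inhibitor of growth), compound 2 gives 30200 nM. Going by the values given here, compound 3 gives 38900 nM, and the step of a 1.3-fold higher number from compound 2 to compound 3 (0.11 log units; within the scatter) is the only comparison available between two numbers. Compound 1 reports only a limit of the assay, < 100000 nM, which is the limit of < 100000 nM in this assay, at which 1 of the 3 values shown sits; it gives no number to compare with.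

Compound 3 therefore stands alongside compound 2 within the scatter, with no third number to place it against.

Compound 4, `Nc1cc(N)c2nc(-c3ccccc3)c(NCc3ccc(F)cc3)nc2c1`, differs from compound 3 in one place: (4-fluorobenzyl)amino in place of 4-fluorophenoxy on an aromatic carbon. Among the compounds with values here, no measured step touches this exact change. Within the data shown here, the one step that exists, from compound 2 to compound 3, swapped the atom linking the ring to the fluorinated aryl group and stayed within the scatter. On that basis a step no larger than the scatter is expected, a 1.1-fold lower number from compound 3 to compound 4 (0.05 log units; within the scatter), though a linker that adds a carbon and a hydrogen-bond donor has not been tested here. The expected value for compound 4 is 35000 nM, estimated to lie between 10000 nM and 100000 nM.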

Compound 4, concentration for total growth inhibition: 13500 nM
The estimate for compound 4 lay 2.6-fold (0.41 log units) above the measured number; the range from low to high includes it.
By their numbers in this assay, from the lowest: compound 4; then compounds 2 and 3 (each within the scatter of the next).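

The position next to the ring nitrogen does respond to its linker in this assay, which the sulfur and oxygen links of compounds 2 and 3 could not show because their values lie within the scatter of each other. The (4-fluorobenzyl)amino group gives a modest step beyond the scatter against each of them (a 2.9-fold lower number from compound 3 to compound 4 (0.46 log units; beyond the scatter); a 2.2-fold lower number from compound 2 to compound 4 (0.35 log units; beyond the scatter)), so the link can be changed here with a measurable result. Nothing shown here explains this step.

The new group differs from the old ones by both a nitrogen link and an added carbon, and these two changes cannot be told apart here. A (4-fluorophenyl)amino group, with the nitrogen but no added carbon, and a (4-fluorobenzyl)oxy group, with the carbon but no nitrogen, would each test one of them.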